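Swapping 4-methoxyphenyl for 2,4-dichlorophenyl in a cytotoxicity series

This account rests on a few compounds, and the source may have more. Where it says the series, first, only, none or still open, it means among the compounds named here.

Compound 1 `CNC(=O)c1cc(Oc2ccc(C(=O)/C=C/c3ccc(Cl)c(Cl)c3)cc2)ccn1`: 33700 nM
Compound 2 `CNC(=O)c1cc(Oc2ccc(C(=O)/C=C/c3ccc(F)cc3Cl)cc2)ccn1`: 21100 nM
Compound 3 `CNC(=O)c1cc(Oc2ccc(C(=O)/C=C/c3ccc(OC)cc3)cc2)ccn1`: > 50000 nM (a limit)

All three compounds were tested in a functional assay on A549 cells (Homo sapiens) for cytotoxicity, read by MTT assay, with a stated time of 72 h; a higher number here means a weaker inhibitor, a lower number a stronger inhibitor. Compound 3 stands at > 50000 nM, which is a limit of the assay and not a number.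

Compound 4 `CNC(=O)c1cc(Oc2ccc(C(=O)/C=C/c3ccc(Cl)cc3Cl)cc2)ccn1` has not been measured yet. It differs from compound 3 by one change: 2,4-dichlorophenyl in place of 4-methoxyphenyl on a double-bonded chain carbon bound to a double-bonded chain carbon.

Within the data shown here, three measured steps bear on this change. Two of them put a 4-methoxyphenyl group in place of a chlorine-bearing ring: an at least 2.3-fold higher number from compound 2 to compound 3 (0.37 log units; beyond the scatter), and an at least 1.4-fold higher number from compound 1 to compound 3 (0.17 log units; that floor lies within the scatter). Read backwards, they point to a lower number once the 4-methoxyphenyl group leaves. The third step, a 1.6-fold lower number from compound 1 to compound 2 (0.20 log units; within the scatter), suggests that the exact chlorine-bearing ring may matter little, so compound 4 is expected to land near the values of compound 1 and compound 2.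

The expected step is an at least 2.0-fold lower number from compound 3 to compound 4 (0.30 log units; that floor lies within the scatter). For compound 4 the estimate is 25000 nM, with an expected range of 12000 nM to 50000 nM.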

Compound 4, half-maximal inhibitory concentration: 9460 nM
Compound 4: middle estimate off by 2.6-fold (0.42 log units), on the high side; the whole stated range lies above it.
By their numbers in this assay, from the lowest: compound 4; then compounds 2 and 1 (each within the scatter of the next). At a limit, above all of these: compound 3.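

The exact pattern on the chlorine-bearing ring matters more than compounds 1 and 2 alone suggested: in this assay, 2,4-dichlorophenyl gives a 2.2-fold lower number from compound 2 to compound 4 (0.35 log units; beyond the scatter) and a 3.6-fold lower number from compound 1 to compound 4 (0.55 log units; beyond the scatter), whereas the step between those two earlier compounds stayed within the scatter. Compound 4 therefore has the lowest number of the four, and the change under test gives an at least 5.2-fold lower number from compound 3 to compound 4 (0.72 log units; beyond the scatter). That step is only a floor, since compound 3 stands at a limit and not at a measured number: the limit of > 50000 nM in this assay, at which 1 of the 4 values shown sits.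

The compounds shown leave open whether both chlorines are needed, and a phenyl ring carrying only one chlorine would help to test this. They also leave open how a ring bearing an amine or a carboxylic acid at this place would compare in this assay.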